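Chloro in place of fluoro on compound 2

The source may report more compounds than this note shows. Statements on the series, on what has been measured and on what is new or still open speak of the compounds shown alone.

Measured in a functional assay on the whole organism with Rattus norvegicus as the target, in the maximal electroshock model; on this read-out higher numbers stand for an effect only at larger amounts of compound and lower numbers for an effect already at smaller amounts:
compound 1 `CNc1ncnc2c1ncn2Cc1c(F)cccc1F` gives 2.7 mg/kg.
compound 2 `CN(C)c1ncnc2c1ncn2Cc1c(F)cccc1F` gives 3.8 mg/kg.
compound 3 `CNc1ncnc2c1ncn2Cc1cccc(F)c1F` gives only a limit, > 50 mg/kg.

Compound 2 holds the higher of the two numbers; its nearest neighbour is compound 1, and a 1.4-fold higher number from compound 1 to compound 2 (0.15 log units; within the scatter) lies within the scatter. Compound 3 sits at the limit of > 50 mg/kg in this assay, at which 1 of the 3 values shown sits. Compound 1 and compound 3 differ only in the placement of a fluoro, and one gives a number while the other gives a limit.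

Compound 4 `CN(C)c1ncnc2c1ncn2Cc1c(F)cccc1Cl` is compound 2 with chloro in place of fluoro on an aromatic carbon. Within the data shown here, no measured step changes a halogen; the only step, a 1.4-fold higher number from compound 1 to compound 2 (0.15 log units; within the scatter), concerns the nitrogen and lay within the scatter. The expected step of a 1.1-fold higher number from compound 2 to compound 4 (0.02 log units; within the scatter) is therefore small, with no direction claimed beyond the scatter. Compound 4 is estimated at 4 mg/kg, in the range 1.5 mg/kg to 12 mg/kg.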

Compound 4, dose for half-maximal effect: 10 mg/kg
The estimate for compound 4 lay 2.5-fold (0.40 log units) below the measured number; low and high end bracket the measured number.
By their numbers in this assay, from the lowest: compounds 1 and 2 (each within the scatter of the next); then compound 4. At a limit, above all of these: compound 3.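

In this assay chloro in place of fluoro on an aromatic carbon ortho to a large group gives a 2.6-fold higher number from compound 2 to compound 4 (0.42 log units; beyond the scatter) and so shows that this position responds to the identity of the halogen, which the step on the nitrogen did not reveal. The step is modest, and compound 4 still gives a number rather than a limit.

On these data alone, whether bromo, methyl or methoxy at this position would stay close to compound 2 remains open, as does whether the same change on compound 1 gives a similar step. Nothing measured here gives a cause for the step.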